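Pyrrolidine diastereomer switch on the cyanophenyl ether series

A few compounds are considered here, and "the series" means these few. Any claim that something is new, unique, unknown or untested is made for them only; others in the source may bear on it.

Notes on the series. Going by the values given here, compound 1 `N#Cc1ccc(OC[C@@H]2CN(S(=O)(=O)c3ccc(Cl)cc3Cl)C[C@H]2O)cc1F` is one of two compounds measured so far in an assay on cells for antagonist activity at transient receptor potential cation channel subfamily V member 4 (Homo sapiens), read by FLIPR and calcium flux, with a stated time of 10 min (on this read-out lower numbers stand for stronger inhibition and higher numbers for weaker inhibition), where compound 1 gives 1000 nM. Compound 2 `N#Cc1ccc(O[C@H]2CN(S(=O)(=O)c3ccc(Cl)cc3Cl)C[C@@H]2CO)cc1F` carries the aryl ether and the hydroxyl-bearing carbon in exchanged positions on the shared core; in this assay compound 2 gives 200 nM, the lower of the two numbers, with compound 1 standing highest. Among the compounds with values here, no step between the two measured compounds is available for a single change.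

Compound 3 `N#Cc1ccc(OC[C@H]2CN(S(=O)(=O)c3ccc(Cl)cc3Cl)C[C@H]2O)cc1F` is the next compound to be measured. Compound 3 differs from compound 1 as follows: the two compounds have the same atoms and bonds and differ only in configuration as drawn: 1 of 2 stereo elements differ; a stereocentre at a saturated ring carbon is drawn S in compound 1 and R in compound 3. Nothing in the measured pair indicates how a change of configuration at the ring carbon moves the read-out, so the expected step from compound 1 to compound 3 is a 1.3-fold lower number from compound 1 to compound 3 (0.10 log units; within the scatter), close to none beyond the scatter but with wide uncertainty in either direction. Compound 3 is therefore expected to give about 800 nM, with a range from 200 nM to 3200 nM.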

Compound 3, half-maximal inhibitory concentration: 1500 nM
The estimate for compound 3 lay 1.9-fold (0.27 log units) below the measured number, and the stated range covers the measured number.
By their numbers in this assay, from the lowest: compound 2; then compounds 1 and 3 (each within the scatter of the next).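

Compounds 1 and 3 form the first single-place comparison in the series, and the comparison rests on one point: the fact that compounds 1 and 3 differ only in the configuration as drawn

In this assay, the change from S to R at this saturated ring carbon gives a 1.5-fold higher number from compound 1 to compound 3 (0.18 log units; within the scatter), so the drawn configuration at this position does not separate the pair beyond the scatter. The earlier compounds shown here could not show this, as they offered no step for a single change; for this pair, with the hydroxyl-bearing carbon drawn alike, the stereocentre shows no measurable effect on the read-out.

Going by these compounds, it remains open whether the second stereocentre on the shared core moves the read-out. On these data alone, it also remains open whether the result at this ring carbon would hold with an amine or a carboxylic acid in place of the hydroxyl.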